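This account rests on a few compounds, and the source may have more. Where it says the series, first, only, none or still open, it means among the compounds named here.

Measured compounds:
compound 1, `O=S1(=O)CCC(CNCCCCN(C[C@H]2Cc3ccccc3CN2)[C@H]2CCCc3cccnc32)CC1`, 17 nM in a functional assay on cells for antagonist activity at C-X-C chemokine receptor type 4 (Homo sapiens), read by fluorescence and calcium flux, with stated times of 25 min and 90 s; on this read-out higher numbers stand for weaker inhibition and lower numbers for stronger inhibition;
compound 2, `CC(C)(CN)CCN(C[C@H]1Cc2ccccc2CN1)[C@H]1CCCc2cccnc21`, 69 nM in this assay.

Among the compounds with values here, of these two numbers, compound 2 holds the higher one, and the only comparison available to it is the step of a 4.1-fold higher number from compound 1 to compound 2 (0.61 log units; beyond the scatter), which lies beyond the scatter. Compound 3, `CC(C)(CCN(C[C@H]1Cc2ccccc2CN1)[C@H]1CCCc2cccnc21)CNC1CCOCC1`, has not yet been measured. It differs from compound 2 by oxan-4-yl in place of hydrogen on an amine nitrogen. Within the data shown here, no measured pair shows exactly this change. The step that bears on it is a 4.1-fold higher number from compound 1 to compound 2 (0.61 log units; beyond the scatter), in which the amine of compound 1, a secondary amine carrying a non-aromatic ring with one hetero atom, gave the lower number, and the primary amine of compound 2 gave the higher one. Compound 3 returns to a secondary amine bearing a non-aromatic ring with one hetero atom, so the expectation is a move back toward the number of compound 1, though not necessarily all the way, as the ring now sits on the nitrogen itself. Compound 3 is therefore expected to give 25 nM in this assay, with a range of 10 nM to 60 nM. This estimate means an expected step of a 2.8-fold lower number from compound 2 to compound 3 (0.44 log units; beyond the scatter).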

Compound 3, half-maximal inhibitory concentration: 36.3 nM
Compound 3: middle estimate off by 1.5-fold (0.16 log units), on the low side; the range from low to high includes it.
By their numbers in this assay, from the lowest: compound 1; then compounds 3 and 2 (each within the scatter of the next).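

In this assay, oxan-4-yl in place of hydrogen on an amine nitrogen gives a 1.9-fold lower number from compound 2 to compound 3 (0.28 log units; within the scatter), so at this position the primary amine and the (oxan-4-yl)amino form cannot be told apart, even though the added group is a whole six-membered non-aromatic ring. The wider change on the saturated chain carbon, two bonds along the chain from an amine nitrogen, gives a 2.1-fold higher number from compound 1 to compound 3 (0.33 log units; beyond the scatter), a modest step that leaves compound 1 with the lowest number of the three, its steps to both others lying beyond the scatter. No measured evidence is at hand that would account for either step.

The compounds shown leave open whether an all-carbon cyclohexyl ring or a piperidin-4-yl ring on this amine nitrogen would read differently from oxan-4-yl, and whether a carboxylic acid on the ring would be tolerated there. They also leave open whether a longer chain between the ring and the amine nitrogen would move the number, since the three compounds differ in more than one feature at this end of the molecule.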